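Series notes: thiocarbonyl substituent exchange and expected potency

The compounds below may be only part of what the source reports. "The series", "measured", "known", "first", "only" and "open" are said of these compounds alone.

Compound 1 `O=C1CC2(CCCCC2)Oc2c1ccc1ccccc21` is the parent ketone of the shared core. In a functional assay on MCF7 cells (Homo sapiens) for antiproliferative activity, read by MTT assay, with a stated time of 96 h (a lower number here means a stronger inhibitor, a higher number a weaker inhibitor), compound 1 gives 10700 nM. Compound 2 `CSC(=S)N/N=C1\CC2(CCCCC2)Oc2c1ccc1ccccc21` carries on the same core a hydrazone bearing a thiocarbonyl with a methylsulfanyl group; in this assay compound 2 gives 5100 nM. Going by the values given here, compound 2 therefore holds the lower of the two numbers known so far, and the number of compound 1 sits beyond the scatter above it, so the hydrazone is associated with the lower value in this pair. Compound 3 `S=C(N/N=C1\CC2(CCCCC2)Oc2c1ccc1ccccc21)N1CCCCC1` is the next member and is not yet measured in this assay. Its difference from compound 2 is piperidin-1-yl in place of methylsulfanyl on a thiocarbonyl carbon. Among the compounds with values here, no step between measured compounds covers a change of this kind, so nothing measured fixes its size. The expectation is that the thiocarbonyl hydrazone is retained and that the step of a 1.3-fold lower number from compound 2 to compound 3 (0.13 log units; within the scatter) stays small, at most a modest lowering of the number that just clears the scatter. Compound 3 is estimated at 3800 nM in this assay, with a range from 1300 nM to 11000 nM.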

Compound 3, half-maximal inhibitory concentration: 13400 nM
Compound 3: middle estimate off by 3.5-fold (0.55 log units), on the low side, and the stated range ends below it.
By their numbers in this assay, from the lowest: compound 2; then compounds 1 and 3 (each within the scatter of the next).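

In this assay, the group on a thiocarbonyl carbon has a measurable influence on the read-out: piperidin-1-yl in place of methylsulfanyl gives a 2.6-fold higher number from compound 2 to compound 3 (0.42 log units; beyond the scatter). The thiocarbonyl hydrazone is present in both compounds, so this unit alone does not fix the number, and the lower value of compound 2 depends at least in part on its methylsulfanyl group. No supporting measurement accounts for the direction or size of this step.

Going by these compounds, this single exchange changes several things at once, so it remains open whether the step follows the loss of the sulfur-linked group or the arrival of the ring; a dimethylamino group and a longer sulfur-linked chain such as butylsulfanyl, each on the same thiocarbonyl carbon, would help separate the two. Also open, on these data alone, is whether a ring with a second hetero atom, such as morpholin-4-yl, would fall closer to compound 2 or to compound 3 in this assay.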